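The source may hold more compounds than are shown below. What is called first, only, known or untested is meant among the compounds shown, and "the series" means these compounds.

In a functional assay on KB cells (Homo sapiens) for cytotoxicity, read by MTT assay, with a stated time of 72 h (a lower number here means that less compound is needed, a higher number that more compound is needed for the effect), compound 1 `O=C1/C(=C\c2c(Cl)cccc2Cl)c2ccccc2N1c1c(Cl)cccc1Cl` gives 50 ug/mL. Compound 2 `COc1ccc(/C=C2\C(=O)N(c3c(Cl)cccc3Cl)c3ccccc32)cc1` gives > 100 ug/mL in this assay, and this value is a limit of the assay, not a number. Compound 2 thus stands at the limit of > 100 ug/mL in this assay, at which 1 of the 2 values shown sits, and no exact position can be given for it. Compound 3 `O=C1/C(=C\c2cccc(Cl)c2)c2ccccc2N1c1c(Cl)cccc1Cl` differs from compound 2 on a double-bonded chain carbon bound to a double-bonded ring carbon, where 3-chlorophenyl takes the place of 4-methoxyphenyl: 3-chlorophenyl in place of 4-methoxyphenyl on a double-bonded chain carbon bound to a double-bonded ring carbon. Within the data shown here, one measured step bears on this place, an at least 2.0-fold higher number from compound 1 to compound 2 (0.30 log units; that floor lies within the scatter). Among the measured compounds shown here, it is the only guide, and its true size is unknown. Compound 3 has a chlorine-bearing phenyl at this place, as does compound 1 with its 50 ug/mL, so a modest move towards that value is expected in this assay. For compound 3 a lower number than the limit of compound 2 is expected. The estimated change is an at least 1.5-fold lower number from compound 2 to compound 3 (0.18 log units; that floor lies within the scatter), and its size remains uncertain. For compound 3 the expected value is 65 ug/mL, with an estimated range from 25 ug/mL to 150 ug/mL.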

Compound 3, concentration for half-maximal effect: 2 ug/mL
Estimate against measurement, compound 3: 33-fold (1.51 log units) above; the measured number lies below the stated range.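

In this assay, the place on a double-bonded chain carbon bound to a double-bonded ring carbon turns out to be far more sensitive than the first two compounds could show, with 3-chlorophenyl in place of 4-methoxyphenyl giving an at least 50-fold lower number from compound 2 to compound 3 (1.69 log units; beyond the scatter). Compound 2 sits at a limit of the assay and not at a number, so this step has a floor but no known size: the limit of > 100 ug/mL in this assay, at which 1 of the 3 values shown sits. A chlorine-bearing phenyl at this place is also not enough in itself to give the low value, since compound 1 and compound 3 both carry one and 3-chlorophenyl in place of 2,6-dichlorophenyl still gives a 25-fold lower number from compound 1 to compound 3 (1.40 log units; beyond the scatter).

The compounds shown leave open whether the difference between these two groups lies in the number of chlorines or in where they sit on the phenyl, as both change together in this step. They also leave open how this place would respond to a 3-fluorophenyl group, or to a phenyl carrying an amine or a carboxylic acid.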